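Isobutyl for tert-butyl on the carbamate of compound 2

A few compounds are considered here, and "the series" means these few. Any claim that something is new, unique, unknown or untested is made for them only; others in the source may bear on it.

Within the data shown here, compound 2 `CC(C)(C)OC(=O)N1CCC(Oc2cc(Oc3ccc(/C=C4\SC(=O)NC4=O)cc3)ncn2)CC1` stands at the higher of the two numbers measured so far; in a functional assay on CHO-K1 cells for agonist activity at Glucose-dependent insulinotropic receptor (Homo sapiens), read by cAMP accumulation and immunoassay, with a stated time of 1 h (a lower number here means that less compound is needed, a higher number that more compound is needed for the effect), compound 2 gives 130 nM, while compound 1 `Cc1c(Oc2ccc(/C=C3\SC(=O)NC3=O)cc2)ncnc1OC1CCN(C(=O)OCC(C)C)CC1` gives 75.1 nM, a gap within the scatter. Compound 3 `CC(C)COC(=O)N1CCC(Oc2cc(Oc3ccc(/C=C4\SC(=O)NC4=O)cc3)ncn2)CC1` is compound 2 with one change: isobutyl in place of tert-butyl on an oxygen next to a carbonyl group. Among the measured compounds shown here, no measured step isolates this change; compound 1 carries the isobutyl carbamate on a different core. The step is expected to be small, a 1.4-fold lower number from compound 2 to compound 3 (0.16 log units; within the scatter), downward if anything. Compound 3 is estimated at 90 nM, within 40 nM to 220 nM.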

Compound 3, half-maximal effective concentration: 745 nM
Beside the measured number, compound 3's estimate is 8.3-fold (0.92 log units) below it; the measured number lies above the stated range.
By their numbers in this assay, from the lowest: compounds 1 and 2 (each within the scatter of the next); then compound 3.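

The carbamate position proves sensitive in this assay even to a rearrangement of the same four carbons: isobutyl in place of tert-butyl gives a 5.7-fold higher number from compound 2 to compound 3 (0.76 log units; beyond the scatter). The methyl on the aromatic carbon also matters with the isobutyl carbamate in place, since hydrogen there gives a 9.9-fold higher number from compound 1 to compound 3 (1.00 log units; beyond the scatter). Nothing available explains either step. Still open, from the compounds shown here alone, is whether a straight butyl chain or a cyclopropyl group on the carbamate oxygen would track tert-butyl or isobutyl, and how tert-butyl behaves on the core of compound 1.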